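Thiophene in place of the cyanophenyl arm

The compounds below may be only part of what the source reports. "The series", "measured", "known", "first", "only" and "open" are said of these compounds alone.

Numbers from a functional assay on KB cells (Homo sapiens) for inhibition, with a stated time of 72 h (on this read-out lower numbers stand for stronger inhibition and higher numbers for weaker inhibition), so far:
compound 1 `COc1ccc(S(=O)(=O)N2CCc3cccc(-c4ccc(C#N)cc4)c32)cc1` gives 31.1 nM
compound 2 `COc1ccc(S(=O)(=O)N2CCc3cccc(-c4ccc(N(C)C)cc4)c32)cc1` gives 539 nM
compound 3 `COc1ccc(-c2cccc3c2N(S(=O)(=O)c2ccc(OC)cc2)CC3)cc1` gives 337 nM

Compound 1 stands lowest of the three. The gap to its nearest neighbour is an 11-fold higher number from compound 1 to compound 3 (1.03 log units; beyond the scatter), and to the furthest a 17-fold higher number from compound 1 to compound 2 (1.24 log units; beyond the scatter). Between the two weaker analogues the difference is a 1.6-fold lower number from compound 2 to compound 3 (0.20 log units; within the scatter), so compounds 2 and 3 are not separated.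

Compound 4 `COc1ccc(S(=O)(=O)N2CCc3cccc(-c4cccs4)c32)cc1` differs from compound 1 by thiophen-2-yl in place of 4-cyanophenyl on an aromatic carbon. Among the measured compounds shown here, no measured step exchanges the whole aryl arm, so the two steps that bear on it are those that alter only the substituent of the 4-cyanophenyl: a 17-fold higher number from compound 1 to compound 2 (1.24 log units; beyond the scatter) and an 11-fold higher number from compound 1 to compound 3 (1.03 log units; beyond the scatter), both large and both towards higher numbers. For the measured compounds named here, since the thiophen-2-yl that enters carries no nitrile, a step towards a higher number, beyond the scatter, is expected for compound 4, though with no direct precedent its size is uncertain; the expected step is a 4.8-fold higher number from compound 1 to compound 4 (0.68 log units; beyond the scatter). Compound 4 is estimated at 150 nM, within a range of 40 nM to 600 nM.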

Compound 4, half-maximal inhibitory concentration: 215 nM
Compound 4: the middle estimate sits 1.4-fold (0.16 log units) below what was measured; low and high end bracket the measured number.
By their numbers in this assay, from the lowest: compound 1; then compounds 4, 3 and 2 (each within the scatter of the next, the first and the last beyond it).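

Working notes on this position: the whole aryl arm can be exchanged here, not only its substituent, and in this assay the thiophen-2-yl arm gives a 6.9-fold higher number from compound 1 to compound 4 (0.84 log units; beyond the scatter), so among the four compounds the lowest number stays with the 4-cyanophenyl arm. The thiophen-2-yl arm is not separated from the 4-methoxyphenyl arm, with a 1.6-fold lower number from compound 3 to compound 4 (0.20 log units; within the scatter), but it is separated from the 4-(dimethylamino)phenyl arm, with a 2.5-fold lower number from compound 2 to compound 4 (0.40 log units; beyond the scatter), even though compounds 2 and 3 are not separated from each other. No measurement at hand accounts for these differences.

On these data alone, whether the nitrile alone carries the low number stays open, and a cyanothiophene at this place would test that. As far as these compounds go, how a carboxylic acid or a primary amide on the phenyl arm would read also remains open.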